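The source may hold more compounds than are shown below. What is called first, only, known or untested is meant among the compounds shown, and "the series" means these compounds.

Working notes on the series. The four compounds share one acid core and differ only in small saturated-chain groups on it. Compound 1 is `Cc1ccc(CC(C)(Oc2ccc(C(C)C)cc2)C(=O)O)cc1`, compound 2 is `CCc1ccc(CC(C)(Oc2ccc(C(C)C)cc2)C(=O)O)cc1`, compound 3 is `CCCc1cccc(CC(C)(Oc2ccc(C(C)C)cc2)C(=O)O)c1`, and the still unmeasured compound 4 is `CCCCc1cccc(CC(C)(Oc2ccc(C(C)C)cc2)C(=O)O)c1`. In a functional assay on the whole organism for inhibition, with Rattus norvegicus as the target (on this read-out lower numbers stand for an effect already at smaller amounts and higher numbers for an effect only at larger amounts of compound), compound 1 gives only a limit, < 1 mg/kg. In this assay compound 2 gives 0.1 mg/kg and compound 3 gives 1 mg/kg; compound 3 stands at the higher of the two numbers, with compound 2 the nearer one at a gap beyond the scatter. The change from compound 1 to compound 2 is methyl in place of hydrogen on a saturated chain carbon bound to an aromatic carbon; the step that the limit leaves unreadable from compound 1 to compound 2 cannot be sized because of the limit of < 1 mg/kg in this assay, at which 1 of the 3 values shown sits. The difference between the cores of compound 3 and compound 1 is not broken down here. Compound 4 carries methyl in place of hydrogen on a saturated chain carbon, three bonds along the chain from an aromatic carbon, the same kind of change, though here the carbon sits three bonds along the chain from an aromatic carbon rather than bound to an aromatic carbon. For the measured compounds named here, because the one earlier step of this kind is hidden by the limit of < 1 mg/kg in this assay, at which 1 of the 3 values shown sits, the expected step from compound 3 to compound 4 is set close to nil, a 1.5-fold higher number from compound 3 to compound 4 (0.18 log units; within the scatter). Compound 4 is therefore expected to give about 1.5 mg/kg in this assay, most likely between 0.4 mg/kg and 5 mg/kg.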

Compound 4, dose for half-maximal effect: 1 mg/kg
Estimate against measurement, compound 4: 1.5-fold (0.18 log units) above; the measured number falls inside the stated range.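

In this assay, methyl in place of hydrogen on a saturated chain carbon, three bonds along the chain from an aromatic carbon, gives no change at the digits printed from compound 3 to compound 4 (within the scatter). This shows that, on the core of compound 3, going from propyl to butyl leaves the read-out unmoved within the scatter, but it rests on one pair of compounds and one place on the chain. For the compounds shown here, it does not show that the change carries from one core to another, because the only other step of this kind, which also sits at a different place (on a saturated chain carbon bound to an aromatic carbon), cannot be read, compound 1 giving only a limit: the limit of < 1 mg/kg in this assay, at which 1 of the 4 values shown sits.

The compounds shown leave open whether a longer chain such as pentyl, or a chain ending in an amine, would also leave the read-out unmoved on the core of compound 3. They also leave open how propyl and butyl would read on the core of compound 1.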